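The source may report more compounds than this note shows. Statements on the series, on what has been measured and on what is new or still open speak of the compounds shown alone.

Measured in an ADME assay on HEp-2 cells (Homo sapiens) for cytotoxicity; on this read-out lower numbers stand for higher toxicity in this test and higher numbers for lower toxicity in this test:
- Compound 1 `CC(C)CCn1c(Cn2c(=O)n(C(C)C)c3ccccc32)nc2cc(CNS(C)(=O)=O)ccc21`: 30800 nM
- Compound 2 `C=C(C)n1c(=O)n(Cc2nc3cc(C(=N)N)ccc3n2CCC(C)C)c2ccccc21`: 10800 nM
- Compound 3 `CC(C)CCn1c(Cn2c(=O)n(C(C)C)c3ccccc32)nc2ccc(CO)cc21`: 81600 nM

Compound 3 has the highest of the three numbers, and its gap to each of the other two lies beyond the scatter. Compound 4 `CC(C)CCn1c(Cn2c(=O)n(C(C)C)c3ccccc32)nc2ccc(C(N)=O)cc21` departs from compound 3 in one place, with carbamoyl in place of hydroxymethyl on an aromatic carbon. Among the measured compounds shown here, no pair of measured compounds differs in only one place, so no direct precedent exists for this change. With compound 3 at 81600 nM at the top of the set, a small move to a lower number is expected, possibly within the scatter. The expected step is a 1.6-fold lower number from compound 3 to compound 4 (0.21 log units; within the scatter). For compound 4 the estimated value is 50000 nM, with an expected range of 18000 nM to 130000 nM.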

Compound 4, half-maximal cytotoxic concentration: 49900 nM
Estimate against measurement, compound 4: 1.0-fold (0.00 log units) above, and the stated range covers the measured number.
By their numbers in this assay, from the lowest: compound 2; then compounds 1, 4 and 3 (each within the scatter of the next, the first and the last beyond it).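

In this assay, among the compounds shown here, carbamoyl in place of hydroxymethyl on this aromatic carbon gives a 1.6-fold lower number from compound 3 to compound 4 (0.21 log units; within the scatter), the first step in the set that changes only one place. On this carbon, the exchange of these two uncharged groups, which carry the same counted hydrogen-bond donors and acceptors, stays within the scatter. No available evidence bears on this result. From the compounds shown here alone, what a carboxylic acid, an amine or a longer chain would do on this carbon remains open. So does whether carbamoyl would give a similar result elsewhere on the shared core.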